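Series notes: one more methoxy on the carbonyl-side ring

The source may report more compounds than this note shows. Statements on the series, on what has been measured and on what is new or still open speak of the compounds shown alone.

Measured so far:
- Compound 1, `COc1cc(-c2cc(/C=C/C(=O)c3ccc(N)cc3)[nH]n2)cc(OC)c1OC`: in a functional assay on SK-OV-3 cells (Homo sapiens) for cytotoxicity, read by sulforhodamine B assay, with a stated time of 48 h, tested at 10 uM (a higher number here means a weaker effect of the compound at the concentration tested, a lower number a stronger effect), compound 1 gives -9%.
- Compound 2, `COc1ccc(C(=O)/C=C/c2cc(-c3cc(OC)c(OC)c(OC)c3)n[nH]2)cc1OC`: in this assay compound 2 gives -12%.

Among the compounds with values here, compound 2 stands at one of only two numbers. The other, from compound 1, is separated from it by a number 3 percentage points lower from compound 1 to compound 2 (within the scatter), so the two numbers cannot be told apart. Both sit close to no effect at the tested concentration.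

Compound 3, `COc1cc(C(=O)/C=C/c2cc(-c3cc(OC)c(OC)c(OC)c3)n[nH]2)cc(OC)c1OC`, differs from compound 2 by methoxy in place of hydrogen on an aromatic carbon. The new methoxy sits on an aromatic carbon of a six-membered aromatic ring of carbon only, ortho to a methoxy group and meta to a methoxy group.

Within the data shown here, only one measured step bears on this change, and only loosely: the exchange of the group on the carbonyl carbon, a number 3 percentage points lower from compound 1 to compound 2 (within the scatter), which was within the scatter. Among the measured compounds shown here, no measured step adds a methoxy to an aromatic carbon, so the data give no direction. The expectation for this assay is therefore a step of a number 4 percentage points higher from compound 2 to compound 3 (within the scatter), that is, none beyond the scatter. Compound 3 is estimated at -8%, with a range from -30% to 20%.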

Compound 3, a percentage reported as activity, at one concentration (the size of the read-out at that concentration, not a potency): 5%
Beside the measured number, compound 3's estimate is 13 percentage points below it; the measured number falls inside the stated range.
By their numbers in this assay, from the lowest: compounds 2 and 1 (each within the scatter of the next); then compound 3.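

Within the data shown here, the added methoxy, ortho to a methoxy group and meta to a methoxy group on the carbonyl-side ring, gives the first change beyond the scatter in this short series: in this assay there is a number 17 percentage points higher from compound 2 to compound 3 (beyond the scatter), a modest step toward a weaker effect at the tested concentration. Among these compounds, the earlier exchange on the carbonyl carbon, a number 3 percentage points lower from compound 1 to compound 2 (within the scatter), gave no readable change, so this aromatic carbon is the first place where a single change registers in the read-out, and here a methoxy in place of hydrogen does not strengthen the effect. Nothing at hand bears on why this one methoxy moves the number.

Open, as far as these compounds go, is whether the step belongs to the methoxy itself or would follow any group on this aromatic carbon, for instance a hydroxyl or a chlorine atom, and whether a smaller or larger ether would sit on the same side of compound 2. Among the compounds shown here, with a single tested concentration and only one step at this position, the size of the step remains a reading at that concentration, not a measure of potency.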